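Sulfonyl substituent exchange in a macrocyclic acylsulfonamide series

The source may report more compounds than this note shows. Statements on the series, on what has been measured and on what is new or still open speak of the compounds shown alone.

Measured in an ADME assay on cells (Homo sapiens) for activation; on this read-out higher numbers stand for lower toxicity in this test and lower numbers for higher toxicity in this test:
compound 1 `CCC1(S(=O)(=O)NC(=O)[C@@]23C[C@H]2/C=C\CCCCN(C)C(=O)N[C@@H](CCOc2cc(-c4nc(C(C)C)cs4)nc4c(Cl)c(OC)ccc24)C(=O)N3)CC1` gives 49300 nM
compound 2 `C#C[C@@H]1CCCN1S(=O)(=O)NC(=O)[C@@]12C[C@H]1/C=C\CCCCN(C)C(=O)N[C@@H](CCOc1cc(-c3nc(C(C)C)cs3)nc3c(Cl)c(OC)ccc13)C(=O)N2` gives 21200 nM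

Going by the values given here, compound 2 holds the lower of the two numbers; the single measured step is a 2.3-fold lower number from compound 1 to compound 2 (0.37 log units; beyond the scatter). Compound 3 `COc1ccc2c(OCC[C@@H]3NC(=O)N(C)CCCC/C=C\[C@@H]4C[C@@]4(C(=O)NS(=O)(=O)C4CC4)NC3=O)cc(-c3nc(C(C)C)cs3)nc2c1Cl` differs from compound 2 by cyclopropyl in place of 2-ethynylpyrrolidin-1-yl on a sulfonyl sulfur. No measured step covers cyclopropyl itself; the only step shown says the group on the sulfonyl sulfur moves this assay modestly, so compound 3 is expected to sit between or near the two measured values, closer to compound 1. The estimate for compound 3 is 35000 nM (range 15000 nM to 80000 nM), an expected 1.7-fold higher number from compound 2 to compound 3 (0.22 log units; within the scatter).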

Compound 3, half-maximal cytotoxic concentration: 40400 nM
Compound 3: the middle estimate sits 1.2-fold (0.06 log units) below what was measured, within the range that was stated.
By their numbers in this assay, from the lowest: compounds 2, 3 and 1 (each within the scatter of the next, the first and the last beyond it).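

In this assay, cyclopropyl in place of 2-ethynylpyrrolidin-1-yl on the sulfonyl sulfur gives a 1.9-fold higher number from compound 2 to compound 3 (0.28 log units; within the scatter), so a group of fewer heavy atoms on this sulfur does not separate from the larger ring. Hydrogen in place of ethyl on the saturated ring carbon gives a 1.2-fold lower number from compound 1 to compound 3 (0.09 log units; within the scatter), so the ethyl group makes no readable difference here. No accompanying data bear on these values.

Open, on these data alone, is how an unsubstituted pyrrolidin-1-yl or a dimethylamino group on the sulfonyl sulfur reads in this assay, which would separate the ring nitrogen from the ethynyl group.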